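This account rests on a few compounds, and the source may have more. Where it says the series, first, only, none or still open, it means among the compounds named here.

In an in vitro ADME assay on microsomes from liver (Homo sapiens) for metabolic stability, read by HPLC (a higher number here means faster removal of the compound, a lower number slower removal), compound 1 `NC(=O)[C@@H](CCC(F)(F)F)N(CC1CCCC1)S(=O)(=O)c1ccc(Cl)cc1` gives 229 mL/min/kg and compound 2 `NC(=O)[C@@H](CCC(F)(F)F)N(C[C@H]1CCCO1)S(=O)(=O)c1ccc(Cl)cc1` gives 231 mL/min/kg. Among the compounds with values here, these two numbers lie within the scatter of each other, so compound 2 stands level with the only other compound measured. Within the data shown here, the single measured step, a 1.0-fold higher number from compound 1 to compound 2 (0.00 log units; within the scatter), places oxolan-2-yl where cyclopentyl stood on a saturated chain carbon bound to a sulfonamide nitrogen.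

Compound 3 `NC(=O)[C@@H](CCC(F)(F)F)N(C[C@@H]1CCCO1)S(=O)(=O)c1ccc(Cl)cc1` takes the structure of compound 2 and changes only its drawn geometry: the two compounds have the same atoms and bonds and differ only in configuration as drawn: 1 of 2 stereo elements differ; a stereocentre at a saturated ring carbon is drawn R in compound 2 and S in compound 3. Among the measured compounds shown here, no measured pair tests a change of configuration at this ring carbon, so the data offer no direct precedent. For the measured compounds named here, the measured step bears on it only indirectly, yet it is the sole guide: a 1.0-fold higher number from compound 1 to compound 2 (0.00 log units; within the scatter) shows that replacing the whole ring substituent left the number within the scatter. A change in configuration alone is therefore not expected to produce a shift beyond the scatter, and the estimated step is a 1.1-fold lower number from compound 2 to compound 3 (0.02 log units; within the scatter). The estimate for compound 3 is 220 mL/min/kg, with the result expected to fall between 120 mL/min/kg and 380 mL/min/kg.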

Compound 3, clearance: 210 mL/min/kg
Beside the measured number, compound 3's estimate is 1.0-fold (0.02 log units) above it; the measured number falls inside the stated range.
By their numbers in this assay, from the lowest: compounds 3, 1 and 2 (each within the scatter of the next).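

In this assay, the inversion at the saturated ring carbon gives a 1.1-fold lower number from compound 2 to compound 3 (0.04 log units; within the scatter), the first direct reading of configuration at this position, and the pair isolates that single change: the fact that compounds 2 and 3 differ only in the configuration as drawn

The second drawn form of the ring also behaves like the first when set against the cyclopentyl compound, with a 1.1-fold lower number from compound 1 to compound 3 (0.04 log units; within the scatter). Across compounds 1, 2 and 3, therefore, neither exchanging cyclopentyl for oxolan-2-yl nor changing the configuration at this ring carbon carries the number beyond the scatter, and this holds for both drawn forms of the ring.

The compounds shown leave open whether a different kind of group on this saturated chain carbon, such as an amine, a carboxylic acid or a phenyl ring, would separate from these three in this assay. They also leave open how the number responds to changes elsewhere in the shared core, including the second stereo element, which compounds 2 and 3 share, and the trifluoromethyl end of the chain.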